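Dichlorophenyl for methoxyphenyl on a second core

This account rests on a few compounds, and the source may have more. Where it says the series, first, only, none or still open, it means among the compounds named here.

Compound 1 `CCOC(=O)c1c(-c2cccc(OC)c2)[nH]c2cc(OC)ccc2c1=O` and compound 3 `CCOC(=O)c1c(-c2cccc(OC)c2)[nH]c2cccc(OC)c2c1=O` are built from the same atoms joined differently; the difference between the two cores is not broken down here. In a physicochemical assay for solubility, in phosphate buffer, at pH 7.4 (a higher number here means a more soluble compound, a lower number a less soluble compound), compound 1 gives > 100000 nM, which is a limit of the assay rather than a number. Compound 3 likewise gives > 100000 nM in this assay, again a limit. Compound 2 `CCOC(=O)c1c(-c2ccc(Cl)c(Cl)c2)[nH]c2cc(OC)ccc2c1=O` carries the change 3,4-dichlorophenyl in place of 3-methoxyphenyl on an aromatic carbon on the core of compound 1; in this assay compound 2 gives 17000 nM, so the measured step is an at least 5.8-fold lower number from compound 1 to compound 2 (0.76 log units; beyond the scatter). The size of this step is bounded on one side only, because the limit of > 100000 nM in this assay, at which 2 of the 3 values shown sit, means the starting point of compound 1 is itself a limit.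

Compound 4 `CCOC(=O)c1c(-c2ccc(Cl)c(Cl)c2)[nH]c2cccc(OC)c2c1=O` carries the same change, (3,4-dichlorophenyl in place of 3-methoxyphenyl on an aromatic carbon), on the core of compound 3; the two place descriptions agree word for word, so this is the same change made on the second core. Compound 4 is expected to show a step of an at least 5.8-fold lower number from compound 3 to compound 4 (0.76 log units; beyond the scatter) in this assay, resting on the measured step of an at least 5.8-fold lower number from compound 1 to compound 2 (0.76 log units; beyond the scatter) and on the fact that compound 3, like compound 1, starts at a limit. Compound 4 is therefore estimated at 17000 nM, with a plausible range of 5000 nM to 60000 nM in this assay.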

Compound 4, solubility: 39000 nM
Compound 4: middle estimate off by 2.3-fold (0.36 log units), on the low side, within the range that was stated.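

In this assay, the change to 3,4-dichlorophenyl from 3-methoxyphenyl runs in the same direction on the two cores shown, with an at least 5.8-fold lower number from compound 1 to compound 2 (0.76 log units; beyond the scatter) on the first and an at least 2.5-fold lower number from compound 3 to compound 4 (0.40 log units; beyond the scatter) on the second, so this pair agrees in direction and sets no general rule for the series. Compound 3 gives > 100000 nM, which is a limit of the assay. Whether the change has the same size on both cores cannot be read, because each step starts from a limit rather than a number: the limit of > 100000 nM in this assay, at which 2 of the 4 values shown sit.

The compounds shown leave open whether the same direction holds for other groups in this place, such as a phenyl ring carrying an amine or a carboxylic acid, since only 3-methoxyphenyl and 3,4-dichlorophenyl appear there. They also leave open whether the change carries over when the ethoxycarbonyl group, which is common to all four compounds, is replaced by another group such as a carboxylic acid or an amide.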